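A few compounds are considered here, and "the series" means these few. Any claim that something is new, unique, unknown or untested is made for them only; others in the source may bear on it.

Compound 1 `CC1(C)Oc2ccc(C#N)cc2[C@@H](n2ccccc2=O)[C@@H]1O` and compound 2 `CC1(C)Oc2ccc(C(F)(F)F)cc2[C@@H](n2ccccc2=O)[C@@H]1O` share one core. In a functional assay (trachea) for inhibition, with Cavia porcellus as the target (a higher number here means a weaker inhibitor, a lower number a stronger inhibitor), compound 1 gives 760 nM and compound 2 gives 540 nM. The change between the two is trifluoromethyl in place of cyano on an aromatic carbon, and the step it made is a 1.4-fold lower number from compound 1 to compound 2 (0.15 log units; within the scatter). Compound 3 `CC1(C)C=C(n2ccccc2=O)c2cc(C#N)ccc2O1` carries cyano on a different core; the difference between the two cores is not broken down here. In this assay compound 3 gives 89 nM, the lowest of the three numbers, with its steps to compound 1 and compound 2 both beyond the scatter. Compound 4 `CC1(C)C=C(n2ccccc2=O)c2cc(C(F)(F)F)ccc2O1` differs from compound 3 by trifluoromethyl in place of cyano on an aromatic carbon, the same change at the same place as seen between compound 1 and compound 2. The expected step is a 1.3-fold lower number from compound 3 to compound 4 (0.10 log units; within the scatter), resting on a 1.4-fold lower number from compound 1 to compound 2 (0.15 log units; within the scatter). Compound 4 is expected at 70 nM, between 30 nM and 170 nM.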

Compound 4, half-maximal inhibitory concentration: 56 nM
Beside the measured number, compound 4's estimate is 1.3-fold (0.10 log units) above it; low and high end bracket the measured number.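

Trifluoromethyl in place of cyano on an aromatic carbon gives steps of matching size on the two cores in this assay: the same change on two cores in this assay, a 1.4-fold lower number (0.15 log units; within the scatter) from compound 1 to compound 2 and a 1.6-fold lower number (0.20 log units; within the scatter) from compound 3 to compound 4, 1.1-fold (0.05 log units) apart, within the scatter of two such steps

The new step reads a 1.6-fold lower number from compound 3 to compound 4 (0.20 log units; within the scatter), so on both cores this change leaves the number within the scatter, and the carry-over holds for compounds 1 to 4 only. Neither step is beyond the scatter, so this does not show how a change with a larger step would carry from one core to the other, nor how this change behaves on any further core.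

On these data alone, an amine, a carboxylic acid or a longer chain on the same aromatic carbon remains open. As far as these compounds go, whether such groups would give matching steps on the two cores also remains open.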